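The compounds below may be only part of what the source reports. "The series", "measured", "known", "first", "only" and "open" are said of these compounds alone.

Compound 1, `CSc1ccc(OCc2ccc(F)cc2F)c(C2=C(c3cccc(C(=O)O)c3)CCC2)c1`, in an assay on isolated protein for inhibition of prostaglandin E2 receptor EP3 subtype (Homo sapiens) (on this read-out higher numbers stand for weaker inhibition and lower numbers for stronger inhibition), gives < 3170 nM, which is a limit of the assay rather than a number.
Compound 2, `O=C(O)c1cccc(C2=C(c3cc(Cl)ccc3OCc3ccccc3)CCC2)c1`, in this assay gives < 3170 nM, again a limit.
Compound 3, `O=C(O)c1cccc(C2=C(c3cc(Br)ccc3OCc3ccccc3)CCC2)c1`, in this assay gives < 3170 nM, again a limit.

Compound 3 therefore stands only at a limit: all three values sit at the limit of < 3170 nM in this assay, at which 3 of the 3 values shown sit, so none of the three compounds can be told apart from another. Among the compounds with values here, the one measured step, a step that the two limits leave unreadable from compound 2 to compound 3, is the only one that bears on the change ahead, and its size cannot be read. Compound 4, `CSc1ccc(OCc2ccccc2)c(C2=C(c3cccc(C(=O)O)c3)CCC2)c1`, differs from compound 3 by methylsulfanyl in place of bromo on an aromatic carbon. With no readable step to lean on, no shift beyond the scatter is expected in this assay. For compound 4 the expected step is a step that the limit leaves unreadable from compound 3 to compound 4. For compound 4 the estimate is 400 nM, with a range from 40 nM to 3170 nM.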

Compound 4, half-maximal inhibitory concentration: < 3170 nM
Compound 4: no number, only a limit (the forecaster's own chance of this, stated with the estimate: 60%); the middle value lies beyond the limit too.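

Compound 4 also gives only a limit, so its steps from compound 1, compound 2 and compound 3 cannot be read: the limit of < 3170 nM in this assay, at which 4 of the 4 values shown sit.

The compounds shown leave open how strongly each one acts in this assay, and whether chloro, bromo or methylsulfanyl makes any difference there.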